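From compound 3 to compound 4: one group exchanged

The compounds below may be only part of what the source reports. "The series", "measured", "known", "first", "only" and "open" are said of these compounds alone.

In a physicochemical assay for lipophilicity, at pH 7.4 (on this read-out lower numbers stand for lower lipophilicity and higher numbers for higher lipophilicity), compound 3 (`COc1ccccc1-c1nc(-c2nnc(C)o2)c(O)c2ncccc12`) gives 3.8, the higher of the two numbers available and beyond the scatter from compound 1 (`Cc1n[nH]c(-c2ncc3c(N(C)C)ccnc3c2O)n1`), which gives -0.6 on the same read-out. Compound 2 (`Cc1n[nH]c(-c2cc3ncccc3c(-c3ccccc3)n2)n1`) adds no number: its entry reads "not determined" (no result reported) here. Compound 4 (`CNC(=O)c1nc(-c2ccccc2OC)c2cccnc2c1O`) departs from compound 3 in one place: methylcarbamoyl in place of 5-methyl-1,3,4-oxadiazol-2-yl on an aromatic carbon, on an aromatic carbon ortho to a hydroxy group. For the measured compounds named here, no measured pair differs in one place only, so the expectation rests on this change alone. A moderate fall in this assay is expected, with the estimated step being a number 0.60 log units lower from compound 3 to compound 4 (beyond the scatter), just beyond the scatter. Compound 4 is expected at 3.2, within an estimated range from 2.5 to 3.9 on this read-out.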

Compound 4, distribution coefficient: 4.2
Compound 4: middle estimate off by 1.00 log units, on the low side, and the stated range ends below it.
By their numbers in this assay, from the lowest: compound 1; then compound 3; then compound 4.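

Exchanging 5-methyl-1,3,4-oxadiazol-2-yl for methylcarbamoyl on this aromatic carbon, ortho to a hydroxy group, gives a number 0.40 log units higher from compound 3 to compound 4 (beyond the scatter) in this assay. For the compounds shown here, this is the first step in the set between compounds that differ in one place, and it shows that the ring-free group, with fewer heavy atoms and a hydrogen-bond donor, does not lower the read-out at this position. Nothing given here explains this step. Open, going by these compounds, is how a carboxylic acid or a dimethylcarbamoyl group would read at this position. Also open, on these data alone, is whether the same exchange gives a similar step without the 2-methoxyphenyl group.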